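Methoxy in Place of Methylsulfanyl: Notes on Compound 3

This account rests on a few compounds, and the source may have more. Where it says the series, first, only, none or still open, it means among the compounds named here.

Of the compounds shown here, two of the shared core have been measured in a functional assay on the whole organism for inhibition, with Digitaria ciliaris as the target, with a stated time of 72 h, tested at 10 mg/L; a lower number here means less inhibition of growth, a higher number more inhibition of growth at the concentration tested. Compound 1 `CSc1cc(C)nc(NC(=S)NC(=O)c2c(-c3ccc(Cl)cc3Cl)noc2C)n1` gives 26.7% and stands highest of the two numbers. Compound 2 `COc1cc(Cl)nc2n/c(=N/C(=O)c3c(-c4ccc(Cl)cc4Cl)noc3C)sn12` gives 16.5% in this assay, and the gap between compound 1 and compound 2 lies beyond the scatter; the two structures differ in more than one place, so no single step can be read from that pair.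

Compound 3 `COc1cc(C)nc(NC(=S)NC(=O)c2c(-c3ccc(Cl)cc3Cl)noc2C)n1` has not yet been measured in this assay. From compound 1 it differs in one place: methoxy in place of methylsulfanyl on an aromatic carbon. Among the measured compounds shown here, no measured pair shows this exchange, so its effect in this assay is unknown from the present numbers. The exchange is small, and a step of about the scatter or less is expected, with the lower side slightly favoured, because compound 1 itself sits only moderately high at 26.7%. For compound 3 the value in this assay is estimated at 23%, within 10% to 38%. The estimated step is a number 3.7 percentage points lower from compound 1 to compound 3 (within the scatter).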

Compound 3, percent growth inhibition at one concentration: 30.2%
Beside the measured number, compound 3's estimate is 7.2 percentage points below it, and the stated range covers the measured number.
By their numbers in this assay, from the lowest: compound 2; then compounds 1 and 3 (each within the scatter of the next).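

In this assay, the exchange on an aromatic carbon, next to the ring nitrogen, gives a number 3.5 percentage points higher from compound 1 to compound 3 (within the scatter), the first single-place step available in the series. The 4-methyl-6-(methylsulfanyl)pyrimidin-2-yl and 4-methoxy-6-methylpyrimidin-2-yl forms therefore cannot be told apart by this read-out at the concentration tested, and sulfur and oxygen are interchangeable here as far as these two compounds show. Nothing at hand speaks to a reason for this outcome.

Open, going by these compounds, is whether this place tolerates a group that differs more from the two seen so far, such as an amine like dimethylamino or a longer chain like butoxy, since two close neighbours say nothing about how far the result extends. On these data alone, compound 1 and compound 3 also share the methyl group on the same ring, so what an ethyl group or a bare hydrogen would do there remains unknown from these numbers.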